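The source may report more compounds than this note shows. Statements on the series, on what has been measured and on what is new or still open speak of the compounds shown alone.

In a functional assay on ileum for antagonist activity at histamine H1 receptor (Cavia porcellus) (a higher number here means weaker binding, a lower number tighter binding), compound 1, `Cc1ccc(C(CC/N=C(\N)NCCCc2c[nH]cn2)c2ccccn2)cc1`, gives 148 nM, while compound 2, `N=C(NCCCc1c[nH]cn1)NCCC(c1ccc(F)cc1)c1ccccn1`, gives 22.4 nM. Compound 2 therefore stands at the lower of the two numbers, and the gap between these two values lies beyond the usual scatter of repeated measurements. Compound 3, `N=C(NCCCc1c[nH]cn1)NCCC(c1ccccn1)c1ccccc1F`, has not yet been tested in this assay. It keeps the shared core of compound 2 and differs from it in one place only: 2-fluorophenyl in place of 4-fluorophenyl on a saturated chain carbon bound to an aromatic carbon and a saturated chain carbon. Going by the values given here, no step between two measured compounds of this kind is available, so the size of the change can only be guessed; a small loss of binding, of a size just beyond the scatter, seems the most plausible expectation, though a number close to that of compound 2 cannot be ruled out. Compound 3 is expected to give about 60 nM, within a range from 20 nM to 200 nM. The expected step of a 2.7-fold higher number from compound 2 to compound 3 (0.43 log units; beyond the scatter) is thus a modest weakening.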

Compound 3, dissociation constant: 437 nM
The estimate for compound 3 lay 7.3-fold (0.86 log units) below the measured number, outside the stated range (above it).
By their numbers in this assay, from the lowest: compound 2; then compound 1; then compound 3.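

In this assay, moving the fluorine while keeping the same atoms gives a 20-fold higher number from compound 2 to compound 3 (1.29 log units; beyond the scatter) and so counts as a large loss of binding. The earlier compounds shown here could not show that this place on the saturated chain carbon responds so strongly to the arrangement of a group, not only to its make-up. The 4-fluorophenyl and 2-fluorophenyl groups match in every count given here, yet they are far from interchangeable in this pair. No measurement at hand gives a reason for this loss.

On these data alone, it remains open whether the loss is specific to 2-fluorophenyl or would also appear with 2-chlorophenyl or 2-methylphenyl. Without an unsubstituted phenyl group for comparison, it also cannot be said whether the fluorine in 2-fluorophenyl weakens binding or the fluorine in 4-fluorophenyl strengthens it.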